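The compounds below may be only part of what the source reports. "The series", "measured", "known", "first", "only" and "open" are said of these compounds alone.

In a functional assay on MDA-MB-231 cells (Homo sapiens) for cytotoxicity, read by MTT assay, with a stated time of 96 h (a higher number here means a weaker inhibitor, a lower number a stronger inhibitor), compound 1 `CC[C@H](NC)C(=O)N[C@@H]1C(=O)N2[C@@H](CC[C@@H]1CCNC(=O)NCc1ccccc1)CC[C@H]2C(=O)NC(c1ccccc1)c1ccccc1` gives 1200 nM and compound 2 `CCNCC[C@H]1CC[C@H]2CC[C@@H](C(=O)NC(c3ccccc3)c3ccccc3)N2C(=O)[C@H]1NC(=O)[C@@H](N)CC` gives 8000 nM as the higher of the two numbers. Compound 2 therefore stands as the weaker of the pair, by a gap beyond the usual scatter. The two differ in more than one place, so that gap cannot be tied to any single group. Compound 3 `CCNCC[C@H]1CC[C@H]2CC[C@@H](C(=O)NC(c3ccccc3)c3ccccc3)N2C(=O)[C@H]1NC(=O)[C@H](CC)NC` is compound 2 with one change (methyl in place of hydrogen on an amine nitrogen), methyl in place of hydrogen on an amine nitrogen, which turns 1-aminopropyl into 1-(methylamino)propyl. For the measured compounds named here, no measured pair shows this change alone. Compound 1 also carries 1-(methylamino)propyl and its 1200 nM is the lower number, so a moderate step toward a lower number, beyond the scatter, is expected in this assay here. The step expected is a 4.4-fold lower number from compound 2 to compound 3 (0.65 log units; beyond the scatter) on this estimate. For compound 3 the estimate is 1800 nM (range 500 nM to 5000 nM).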

Compound 3, half-maximal inhibitory concentration: 1300 nM
Beside the measured number, compound 3's estimate is 1.4-fold (0.14 log units) above it; low and high end bracket the measured number.
By their numbers in this assay, from the lowest: compounds 1 and 3 (each within the scatter of the next); then compound 2.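

In this assay, for the compounds shown here, methyl in place of hydrogen on an amine nitrogen gives a 6.2-fold lower number from compound 2 to compound 3 (0.79 log units; beyond the scatter) and so shows, as no earlier pair could, what this one change does on its own when 1-aminopropyl becomes 1-(methylamino)propyl. With 1-(methylamino)propyl in place, ethyl in place of benzylcarbamoyl on the other amine nitrogen gives a 1.1-fold higher number from compound 1 to compound 3 (0.03 log units; within the scatter) and so makes no difference that can be told from scatter in this assay. Nothing measured here explains either result.

The compounds shown leave open whether a longer chain such as propyl, or a second methyl giving dimethylamino, would carry the step further. Going by these compounds, they also show the methyl step only in compounds carrying ethyl on the other amine nitrogen, so its size with benzylcarbamoyl there remains unknown.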